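The compounds below may be only part of what the source reports. "The series", "measured", "known", "first", "only" and "open" are said of these compounds alone.

Among the measured compounds shown here, in a functional assay on K562/A02 cells (Homo sapiens) for antiproliferative activity, read by MTT assay (on this read-out higher numbers stand for weaker inhibition and lower numbers for stronger inhibition), compound 1 `Cc1ccccc1/C(=N/NC(=S)NCCCCCC(=O)NO)c1ccccc1` gives 4220 nM, the higher of the two numbers measured so far and therefore the weaker inhibition. Compound 2 `C/C(=N\NC(=S)NCCCCCC(=O)NO)c1ccc(F)cc1` gives 1020 nM, and the gap between these two values lies beyond the usual scatter of repeated measurements. The two structures differ in more than one place, so that gap cannot be pinned on any single group.

Compound 3 `O=C(CCCCCNC(=S)N/N=C(\c1ccccc1)c1cccc([N+](=O)[O-])c1)NO` has not been measured yet. It keeps the core of compound 1 and changes one group, with 3-nitrophenyl in place of 2-methylphenyl on a carbon with a double bond to nitrogen. For the measured compounds named here, no measured pair shows what this swap does, so the expectation rests on little. Compound 1 stands at the top of the range at 4220 nM, while compound 2 shows at 1020 nM that lower numbers occur in this small set. A small move toward stronger inhibition, within the scatter of this assay, is therefore expected, as the estimated 1.7-fold lower number from compound 1 to compound 3 (0.23 log units; within the scatter) shows. For compound 3 the estimate is 2500 nM, with an expected range from 800 nM to 7500 nM.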

Compound 3, half-maximal inhibitory concentration: 940 nM
For compound 3 the middle estimate is 2.7-fold (0.42 log units) above the measured one; the measured number falls inside the stated range.
By their numbers in this assay, from the lowest: compounds 3 and 2 (each within the scatter of the next); then compound 1.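

In this assay, putting 3-nitrophenyl in place of 2-methylphenyl on the carbon with a double bond to nitrogen gives a 4.5-fold lower number from compound 1 to compound 3 (0.65 log units; beyond the scatter). Among the compounds shown here, this is the first change in the set that can be tied to a single place, since the two earlier compounds differ in more than one, and it shows that the group at this position can move the number by more than the usual scatter while the rest of the molecule stays the same. Nothing available here explains why this swap has this effect.

The swap also removes a methyl group and brings in a nitro group on a single ring, so the compounds shown cannot tell whether losing the one or gaining the other accounts for the step. As far as these compounds go, it remains open how a plain phenyl, a 3-aminophenyl or a 3-carboxyphenyl would behave in the same place, and so whether this result reflects something specific to the nitro group or a wider trend at this position.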